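Swapping one aromatic ring for another on the shared core

A few compounds are considered here, and "the series" means these few. Any claim that something is new, unique, unknown or untested is made for them only; others in the source may bear on it.

Compound 3 `CCCCN(c1nc2c(-c3nccn3C)cccc2o1)[C@H](C)c1ccc(-c2ccccc2-c2nnn[nH]2)cc1` stands highest in an ADME assay on the whole organism (plasma, Macaca fascicularis) for protein binding, read by LC-MS, using equilibrium dialysis and cassette dosing, with a stated time of 24 h, at a dose of 1 mg/kg by the oral route (a higher number here means a larger unbound share of the compound, a lower number a smaller unbound share), among three measured compounds: it gives 0.00299. Compound 1 `CCCCN(c1nc2c(C(=O)O)cccc2o1)[C@H](C)c1ccc(-c2ccccc2-c2nnn[nH]2)cc1` gives 0.000285, and compound 2 `CCCCN(c1nc2c(NS(C)(=O)=O)cccc2o1)[C@H](C)c1ccc(-c2ccccc2-c2nnn[nH]2)cc1` gives 0.000203. The step of a 10-fold higher number from compound 1 to compound 3 (1.02 log units; beyond the scatter) and the step of a 15-fold higher number from compound 2 to compound 3 (1.17 log units; beyond the scatter) are both large, while the step of a 1.4-fold lower number from compound 1 to compound 2 (0.15 log units; within the scatter) is within the scatter. Compound 4 `CCCCN(c1nc2c(-c3ccccn3)cccc2o1)[C@H](C)c1ccc(-c2ccccc2-c2nnn[nH]2)cc1` is not yet measured. It differs from compound 3 in one place: pyridin-2-yl in place of 1-methyl-1H-imidazol-2-yl on an aromatic carbon. Going by the values given here, none of the measured steps exchanges one aromatic ring for another; both large steps replaced carboxy or methanesulfonamido with 1-methyl-1H-imidazol-2-yl, and that group is now the one that leaves. Among the compounds with values here, with no direct precedent, the change in this assay is expected to be small, with compound 4 estimated to end up near compound 3, perhaps somewhat lower, as a step of a 1.4-fold lower number from compound 3 to compound 4 (0.13 log units; within the scatter). For compound 4 the estimate in this assay is 0.0022, within a range from 0.0008 to 0.005.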

Compound 4, unbound fraction: 0.00129
Beside the measured number, compound 4's estimate is 1.7-fold (0.23 log units) above it; low and high end bracket the measured number.
By their numbers in this assay, from the lowest: compounds 2 and 1 (each within the scatter of the next); then compound 4; then compound 3.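

In this assay, exchanging one aromatic ring for another on this aromatic carbon is not neutral: a 2.3-fold lower number from compound 3 to compound 4 (0.37 log units; beyond the scatter) is a modest step beyond the scatter, so 1-methyl-1H-imidazol-2-yl and pyridin-2-yl cannot be treated as interchangeable here. Pyridin-2-yl also stands above both earlier non-ring groups, with a 4.5-fold higher number from compound 1 to compound 4 (0.66 log units; beyond the scatter) in place of carboxy and a 6.4-fold higher number from compound 2 to compound 4 (0.80 log units; beyond the scatter) in place of methanesulfonamido, yet neither step is as large as those printed for 1-methyl-1H-imidazol-2-yl.

The compounds shown leave open whether an aromatic ring without a ring nitrogen, such as phenyl, would keep this higher number. They also leave open where a pyrimidin-2-yl ring or a small amine on the same carbon would fall. Nothing measured here accounts for the gap between the two rings.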